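Notes on benzyl variation in the series

A few compounds are considered here, and "the series" means these few. Any claim that something is new, unique, unknown or untested is made for them only; others in the source may bear on it.

Measured so far:
compound 1 `C=C(Br)C(=O)Nc1cccc(/C=C2\SC(=O)N(Cc3cccc(Cl)c3)C2=O)c1` gives 1700 nM in a functional assay on FM3A cells (Mus musculus) for cytotoxicity, read by cell counting, with a stated time of 2 days; on this read-out higher numbers stand for weaker inhibition and lower numbers for stronger inhibition
compound 2 `C=C(Br)C(=O)Nc1cccc(/C=C2\SC(=O)N(Cc3ccc(F)cc3)C2=O)c1` gives 920 nM in this assay

Going by the values given here, compound 2 and compound 1 sit within the scatter of each other in this assay, the only step being a 1.8-fold lower number from compound 1 to compound 2 (0.27 log units; within the scatter). Compound 3 `C=C(Br)C(=O)Nc1cccc(/C=C2\SC(=O)N(Cc3ccccc3)C2=O)c1` is yet to be measured in this assay. It differs from compound 2 by hydrogen in place of fluoro on an aromatic carbon. Among the compounds with values here, the single step that bears on change at the benzyl group, a 1.8-fold lower number from compound 1 to compound 2 (0.27 log units; within the scatter), stayed within the scatter, so no step beyond the scatter is expected here, and a 1.2-fold higher number from compound 2 to compound 3 (0.08 log units; within the scatter) is the estimated step. Compound 3 is therefore expected to give 1100 nM, with a range of 500 nM to 2500 nM.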

Compound 3, half-maximal inhibitory concentration: 810 nM
For compound 3 the middle estimate is 1.4-fold (0.13 log units) above the measured one; low and high end bracket the measured number.
By their numbers in this assay, from the lowest: compounds 3, 2 and 1 (each within the scatter of the next, the first and the last beyond it).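

In this assay, 4-fluorobenzyl and benzyl cannot be told apart (a 1.1-fold lower number from compound 2 to compound 3 (0.06 log units; within the scatter)), so the fluoro is not required for activity at this position. Hydrogen in place of chloro gives the first step at the benzyl group beyond the scatter, though only a modest one (a 2.1-fold lower number from compound 1 to compound 3 (0.32 log units; beyond the scatter)), while compound 1 and compound 2 stay within the scatter of each other. Nothing on hand accounts for this difference.

Open, on these data alone, is whether an amine or a carboxylic acid on the phenyl ring, or a longer chain in place of the benzyl group, would shift the number further.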